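Dichlorophenyl to Dihydroxyphenyl: What Compound 4 Should Show

The source may report more compounds than this note shows. Statements on the series, on what has been measured and on what is new or still open speak of the compounds shown alone.

In a functional assay on NCI-H460 cells (Homo sapiens) for cytotoxicity, read by MTT assay, with a stated time of 72 h (on this read-out higher numbers stand for weaker inhibition and lower numbers for stronger inhibition), compound 3 `CN(C)CCn1cnnc1-c1cc(Oc2ccc(NC(=O)N/N=C/c3cccc(Cl)c3Cl)cc2F)ccn1` gives 72 nM, the lowest number among the three compounds measured here. Compound 1 `CN(C)CCn1cnnc1-c1cc(Oc2ccc(NC(=O)N/N=C/c3ccccc3)cc2F)ccn1` gives 1780 nM and compound 2 `CN(C)CCn1cnnc1-c1cc(Oc2ccc(NC(=O)N/N=C/c3ccc(O)c(O)c3)cc2F)ccn1` gives 1930 nM, and those two lie within the scatter of each other, as a 1.1-fold higher number from compound 1 to compound 2 (0.04 log units; within the scatter) shows. The steps of a 25-fold lower number from compound 1 to compound 3 (1.39 log units; beyond the scatter) and a 27-fold lower number from compound 2 to compound 3 (1.43 log units; beyond the scatter) mark how far compound 3 stands apart from both.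

Compound 4 `CN(C)CCn1cnnc1-c1cc(Oc2ccc(NC(=O)N/N=C/c3ccc(O)cc3O)cc2F)ccn1` has not yet been measured in this assay. It differs from compound 3 in a single place: 2,4-dihydroxyphenyl in place of 2,3-dichlorophenyl on a carbon with a double bond to nitrogen. Among the measured compounds shown here, two measured steps bear on this change. The steps of a 25-fold lower number from compound 1 to compound 3 (1.39 log units; beyond the scatter) and a 27-fold lower number from compound 2 to compound 3 (1.43 log units; beyond the scatter) show that bringing in 2,3-dichlorophenyl at this carbon is what moves the number so strongly, whereas 3,4-dihydroxyphenyl in place of phenyl, by a 1.1-fold higher number from compound 1 to compound 2 (0.04 log units; within the scatter), changes nothing beyond the scatter. Compound 4 removes the 2,3-dichlorophenyl and carries a dihydroxyphenyl instead, so a large upward step is expected, roughly reversing what the dichlorophenyl brought. Compound 4 is therefore expected to give 1800 nM in this assay, within a range from 700 nM to 4500 nM, an expected step of a 25-fold higher number from compound 3 to compound 4 (1.40 log units; beyond the scatter). For the measured compounds named here, the 2,4-dihydroxyphenyl of compound 4 is not the same as the 3,4-dihydroxyphenyl of compound 2, and no measured compound carries it. The range is kept wide.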

Compound 4, half-maximal inhibitory concentration: 11300 nM
Compound 4: middle estimate off by 6.3-fold (0.80 log units), on the low side; measured number outside the range, above it.
By their numbers in this assay, from the lowest: compound 3; then compounds 1 and 2 (each within the scatter of the next); then compound 4.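

In this assay the exchange at this carbon with a double bond to nitrogen reaches further than a return to the level of compounds 1 and 2, with a 160-fold higher number from compound 3 to compound 4 (2.20 log units; beyond the scatter) as the full span between the two groups. The earlier compounds had shown 3,4-dihydroxyphenyl and phenyl within the scatter of each other, which could have suggested that hydroxyl groups on this ring leave the number unchanged, but a 5.9-fold higher number from compound 2 to compound 4 (0.77 log units; beyond the scatter) and a 6.3-fold higher number from compound 1 to compound 4 (0.80 log units; beyond the scatter) show that the two dihydroxyphenyl groups are not interchangeable and that a dihydroxyphenyl can give a weaker result than plain phenyl. Nothing available here explains why the two dihydroxyphenyl groups differ or why compound 3 stands so far from the others.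

The compounds shown leave open whether the low number of compound 3 needs both chlorines or whether a phenyl carrying a single chlorine would keep it. They also leave open whether a phenyl carrying two methoxy groups in the places of the hydroxyl groups of compound 4 would follow compound 4 or compound 2.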